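The source may report more compounds than this note shows. Statements on the series, on what has been measured and on what is new or still open speak of the compounds shown alone.

Among the measured compounds shown here, in a functional assay on thoracic aorta (strain Wistar) with Aorta (Rattus norvegicus) as the target, with a stated time of 2 h (a lower number here means a stronger inhibitor, a higher number a weaker inhibitor), compound 1 `CCOC(=O)c1c(-c2ccc(F)cc2)cc(-c2ccccc2)nc1N1CCCCC1` gives 346000 nM, the highest of the three numbers measured so far, although the other two lie within the scatter of it. Compound 2 `CCOC(=O)c1c(-c2ccc(C)cc2)cc(-c2ccccc2)nc1N1CCCCC1` gives 175000 nM, and compound 3 `CCOC(=O)c1c(-c2ccc(C)cc2)cc(-c2ccccc2)nc1N1CCN(c2nc(-c3ccccc3)cc(-c3ccc(C)cc3)c2C(=O)OCC)CC1` gives 229000 nM. Compound 4 `CCOC(=O)c1c(-c2ccc(F)cc2)cc(-c2ccccc2)nc1Nc1ccc(OC)cc1` differs from compound 1 by (4-methoxyphenyl)amino in place of piperidin-1-yl on an aromatic carbon. For the measured compounds named here, the only measured step, a 2.0-fold lower number from compound 1 to compound 2 (0.30 log units; within the scatter), concerns a different part of the shared core, and no measured pair shows the present change, so nothing in these numbers points to a step beyond the scatter in this assay in either direction. Compound 4 is therefore expected to give about 300000 nM, with a range from 100000 nM to 900000 nM, which would mean an estimated 1.2-fold lower number from compound 1 to compound 4 (0.06 log units; within the scatter).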

Compound 4, half-maximal inhibitory concentration: 254000 nM
Estimate against measurement, compound 4: 1.2-fold (0.07 log units) above, and the stated range covers the measured number.
By their numbers in this assay, from the lowest: compounds 2, 3, 4 and 1 (each within the scatter of the next).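

In this assay, putting (4-methoxyphenyl)amino in place of piperidin-1-yl on the aromatic carbon next to the ring nitrogen gives a 1.4-fold lower number from compound 1 to compound 4 (0.13 log units; within the scatter). Among the compounds shown here, this is the first measured change at this position, and even with a larger group bringing an aromatic ring and a hydrogen-bond donor, the number stays within the scatter. No measurement available here explains this result. Going by these compounds, whether a plain amino group at this position, or a carboxylic acid in place of the ethoxycarbonyl group, would move the number beyond the scatter remains open.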